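A few compounds are considered here, and "the series" means these few. Any claim that something is new, unique, unknown or untested is made for them only; others in the source may bear on it.

Working notes on the series. The reference compound 1 `CC(=O)c1cccc(-c2nc3c(N)ncnc3n2[C@@H]2O[C@H](COP(=O)(O)OP(=O)(O)OC[C@H]3OC(O)[C@H](O)[C@@H]3O)[C@@H](O)[C@H]2O)c1` shows measurable but weak inhibition in an assay on HEK293 cells for antagonist activity at transient receptor potential cation channel subfamily M member 2 (Homo sapiens), read by patch clamp (on this read-out higher numbers stand for weaker inhibition and lower numbers for stronger inhibition), giving 49000 nM. Compound 2 `O=c1[nH]cnc2c1ncn2[C@@H]1O[C@H](COP(=O)(O)OP(=O)(O)OC[C@H]2OC(O)[C@H](O)[C@@H]2O)[C@@H](O)[C@H]1O` carries a different base on the shared core and is reported in this assay as "not active" (no number reported), so no number can be set for it. Compound 3 `Nc1ncnc2c1nc(N)n2[C@@H]1O[C@H](COP(=O)(O)OP(=O)(O)OC[C@H]2OC(O)[C@H](O)[C@@H]2O)[C@@H](O)[C@H]1O` differs from compound 2 by the exchange (a group of 11 heavy atoms (5 carbon, 6 nitrogen; one five-membered aromatic ring with 2 hetero atoms, one six-membered aromatic ring with 2 hetero atoms) in place of a group of 10 heavy atoms (5 carbon, 4 nitrogen, 1 oxygen; one five-membered aromatic ring with 2 hetero atoms, one six-membered aromatic ring with 2 hetero atoms), on a saturated ring carbon). Among the measured compounds shown here, with compound 2 lacking a number, no measured step is available to anchor compound 3, and the expected size of the change cannot be set against the scatter. Compound 3 is estimated at 100000 nM, in the range 20000 nM to 500000 nM.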

Compound 3, half-maximal inhibitory concentration: "not active" (no number reported)
No number was reported for compound 3; no gap can be computed for the estimate.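

Compound 2 and compound 3 both stand without a number in this assay and so give no readable step. No supporting evidence bears on this result. The compounds shown leave open whether either base retains any measurable inhibition.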